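Aryl hydroxyl for fluoro on a weak alpha-glucosidase inhibitor

The source may hold more compounds than are shown below. What is called first, only, known or untested is meant among the compounds shown, and "the series" means these compounds.

Compound 1: `OC[C@@]1(c2ccc(F)cc2)NC[C@@H](O)[C@@H]1O`, 714000 nM
Compound 2: `CCCCCCCCC[C@@]1(CO)NC[C@H](O)[C@H]1O`, 3700 nM

Of the compounds shown here, two have been measured in an assay on isolated protein for inhibition of lysosomal alpha-glucosidase (Homo sapiens); a lower number here means a stronger inhibitor, a higher number a weaker inhibitor. Compound 1 gives 714000 nM, the highest of the two numbers and therefore the weaker inhibitor. Compound 2 carries a nonyl chain where compound 1 carries the aryl group and differs in other respects as well; compound 2 gives 3700 nM. The gap between these two values is far beyond the usual scatter, but the compounds differ in more than one place, so nothing is said about any single cause.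

Compound 3, `OC[C@@]1(c2ccc(O)cc2)NC[C@@H](O)[C@@H]1O`, is the next compound to be measured in this assay. It differs from compound 1 in one place: hydroxy in place of fluoro on an aromatic carbon. Going by the values given here, no step between measured compounds speaks to this exchange, so the expectation rests only on compound 1 itself. Since the shared core is the same and the aryl group is unchanged in size, the step from compound 1 to compound 3 is expected to be small, of either direction or none beyond the scatter, amounting to a 1.4-fold lower number from compound 1 to compound 3 (0.15 log units; within the scatter). Compound 3 is accordingly estimated at 500000 nM, within 150000 nM to 2000000 nM, with a real chance that this assay returns only a limit for a compound this weak.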

Compound 3, half-maximal inhibitory concentration: 372000 nM
The estimate for compound 3 lay 1.3-fold (0.13 log units) above the measured number, and the stated range covers the measured number.
By their numbers in this assay, from the lowest: compound 2; then compounds 3 and 1 (each within the scatter of the next).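

In this assay, going by these compounds alone, hydroxy in place of fluoro on an aromatic carbon, para to a group of 9 heavy atoms, amounts to a 1.9-fold lower number from compound 1 to compound 3 (0.28 log units; within the scatter), the only comparison here between compounds that differ in one place. At this position, then, a group counted with a hydrogen-bond donor and a hydrogen-bond acceptor can take the place of a fluorine, counted with neither, without a change that can be told from the scatter, and compound 3, at 372000 nM, remains a very weak inhibitor in this assay. No measurement shown here offers an explanation for this outcome.

As far as these compounds go, whether an amine, a carboxylic acid or a methoxy group at the same aromatic carbon would also stay within the scatter of compound 1 remains open, as does the result of a bare hydrogen there. Also open, from the compounds shown here alone, is what a nonyl chain would do in place of the aryl group on the exact core of compound 1, since compound 2 differs from compound 1 in more than one place and its share of that gap cannot be read.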